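This account rests on a few compounds, and the source may have more. Where it says the series, first, only, none or still open, it means among the compounds named here.

Compound 1 `NC(=O)[C@@H](c1ccccc1)N(C(=O)c1ccccc1)[C@@H]1CCc2ccc(Cl)cc21`: 120 nM
Compound 2 `NC(=O)[C@@H](c1ccccc1)N(C(=O)c1ccccc1)[C@@H]1CCc2c(F)cc(F)cc21`: 100 nM
Compound 3 `NC(=O)[C@@H](c1ccccc1)N(C(=O)c1ccccc1)[C@@H]1CCc2c(F)cc(Cl)cc21`: 300 nM

All three were measured in an assay on HEK293T cells for antagonist activity at transient receptor potential cation channel subfamily M member 8 (Homo sapiens), read by fluorescence and calcium flux, with a stated time of 60 min; on this read-out lower numbers stand for stronger inhibition and higher numbers for weaker inhibition. Among these numbers compound 3 stands highest: the steps of a 2.5-fold higher number from compound 1 to compound 3 (0.40 log units; beyond the scatter) and a 3.0-fold higher number from compound 2 to compound 3 (0.48 log units; beyond the scatter) both run up to it, and each is beyond the scatter. Compound 4 `NC(=O)[C@@H](c1ccccc1)N(C(=O)c1cccnc1N)[C@@H]1CCc2c(F)cc(Cl)cc21` has not been measured. It differs from compound 3 in one place: 2-aminopyridin-3-yl in place of phenyl on a carbonyl carbon. Neither measured step bears on this part of the molecule, since both concern the halogen pattern on the other ring. Going by the values given here, no step in the set therefore indicates a direction or size for this change in this assay, and the expectation rests on the value of compound 3 alone. Compound 4 is expected near 250 nM, within 60 nM to 1000 nM. The expected step is a 1.2-fold lower number from compound 3 to compound 4 (0.08 log units; within the scatter).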

Compound 4, half-maximal inhibitory concentration: 170 nM
Beside the measured number, compound 4's estimate is 1.5-fold (0.17 log units) above it; the range from low to high includes it.
By their numbers in this assay, from the lowest: compounds 2, 1, 4 and 3 (each within the scatter of the next, the first and the last beyond it).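

In this assay, 2-aminopyridin-3-yl in place of phenyl on a carbonyl carbon gives a 1.8-fold lower number from compound 3 to compound 4 (0.25 log units; within the scatter), so the assay does not separate the two groups at this position. The halogen steps had said nothing about this part of the molecule; here a larger ring carrying an amine and a ring nitrogen keeps the number of compound 3 within the scatter. No measurement available here explains this result. The compounds shown leave open whether the amine or the ring nitrogen matters, since neither plain pyridin-3-yl nor 2-aminophenyl appears among them. From the compounds shown here alone, whether the same exchange holds on the difluoro core of compound 2 also remains open.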